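Relocating Bromine: From Compound 2 to Compound 3

This account rests on a few compounds, and the source may have more. Where it says the series, first, only, none or still open, it means among the compounds named here.

Two compounds share a common core and differ at one end. Compound 1 `COc1ccc(Br)cc1Nc1cc(NC(=O)Nc2c(Cl)cccc2Cl)ncn1` was tested in a functional assay on PC-9 cells (Homo sapiens) for inhibition, read by MTT assay, with a stated time of 48 h, tested at 10 uM (a higher number here means more inhibition at the concentration tested (going by the name of the read-out), a lower number less inhibition), and gave 69%. Compound 2 `COc1cc(NC(=O)Nc2cc(Nc3ccc(Br)cc3OC)ncn2)cc(OC)c1` gave 83% in this assay, the higher of the two numbers; the gap from compound 1 to compound 2 lies beyond the usual scatter of repeated measurements, so the inhibition of compound 2 in this assay is higher than that of compound 1. Going by the values given here, no step between measured compounds that differ in only one place is available, so the pair offers no direct guide to a small structural change.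

Compound 3 `COc1cc(NC(=O)Nc2cc(Nc3cc(Br)ccc3OC)ncn2)cc(OC)c1` keeps the whole of compound 2 except at one end: 5-bromo-2-methoxyphenyl in place of 4-bromo-2-methoxyphenyl on a nitrogen on an aromatic ring. The same atoms remain, joined differently. Without any measured single-site step, the expected change from compound 2 to compound 3 is small, with no direction favoured and most likely none beyond the scatter. The step from compound 2 to compound 3 is estimated at a number 7 percentage points lower from compound 2 to compound 3 (within the scatter). Compound 3 is therefore expected to give about 76% in this assay, within a range from 55% to 92%.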

Compound 3, a percentage reported as inhibition, at one concentration (the size of the read-out at that concentration, not a potency): 82.5%
Beside the measured number, compound 3's estimate is 6.5 percentage points below it, and the stated range covers the measured number.
By their numbers in this assay, from the lowest: compound 1; then compounds 3 and 2 (each within the scatter of the next).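

In this assay, going by these compounds alone, exchanging 4-bromo-2-methoxyphenyl for 5-bromo-2-methoxyphenyl on a nitrogen on an aromatic ring gives a number 0.5 percentage points lower from compound 2 to compound 3 (within the scatter) and is the first single-place step at this end, so this read-out does not separate the two bromine arrangements at the concentration tested. The other end now has a single-place step as well: 3,5-dimethoxyphenyl in place of 2,6-dichlorophenyl on an amide-type nitrogen gives a number 13.5 percentage points higher from compound 1 to compound 3 (beyond the scatter) in this assay and, unlike the bromine exchange, shows a change that can be told from the scatter. Nothing measured alongside these numbers offers an explanation for either step.

The compounds shown leave open how the 5-bromo-2-methoxyphenyl end would respond if a nitrile took the place of the bromine or an ethoxy group that of the methoxy, and whether an amine or a carboxylic acid on the 3,5-dimethoxyphenyl end would keep the read-out where it stands. They also leave open whether the two bromine arrangements, which read alike at a single concentration, would still read alike across a range of concentrations.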